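Bromophenyl isomers on the aromatic nitrogen

A few compounds are considered here, and "the series" means these few. Any claim that something is new, unique, unknown or untested is made for them only; others in the source may bear on it.

Compound 1 `CC1(C)[C@H]2CC[C@]1(C)N(Cc1cn(-c3ccccc3Br)nn1)C(=O)C2` is the reference of this set. In a functional assay on LoVo cells (Homo sapiens) for inhibition, read by MTT assay, with a stated time of 24 h (on this read-out lower numbers stand for stronger inhibition and higher numbers for weaker inhibition), compound 1 gives 60 nM, the second highest of three numbers; compound 3 `Cc1ccc(-n2cc(CN3C(=O)C[C@@H]4CC[C@@]3(C)C4(C)C)nn2)cc1` gives 50 nM and compound 2 `CC1(C)[C@H]2CC[C@]1(C)N(Cc1cn(-c3ccc(C#N)cc3)nn1)C(=O)C2` gives 90 nM. The steps of a 1.2-fold lower number from compound 1 to compound 3 (0.08 log units; within the scatter) and a 1.5-fold higher number from compound 1 to compound 2 (0.18 log units; within the scatter) both exchange the group on the aromatic nitrogen and both stay within the scatter, as does a 1.8-fold lower number from compound 2 to compound 3 (0.26 log units; within the scatter). Compound 4 `CC1(C)[C@H]2CC[C@]1(C)N(Cc1cn(-c3cccc(Br)c3)nn1)C(=O)C2` differs from compound 1 by 3-bromophenyl in place of 2-bromophenyl on an aromatic nitrogen. The comparisons that bear on this are the two steps from compound 1, which show no movement beyond the scatter for other groups in this place, so no step beyond the scatter is expected in this assay for this change either. For compound 4 the expected value in this assay is 60 nM, within 35 nM to 110 nM, an expected no change at the digits printed from compound 1 to compound 4 (within the scatter).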

Compound 4, half-maximal inhibitory concentration: 30 nM
Estimate against measurement, compound 4: 2.0-fold (0.30 log units) above; the whole stated range lies above it.
By their numbers in this assay, from the lowest: compounds 4, 3, 1 and 2 (each within the scatter of the next, the first and the last beyond it).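

Moving the bromine on the same atoms gives a 2.0-fold lower number from compound 1 to compound 4 (0.30 log units; within the scatter) in this assay, so this isomer change stays inside the scatter. Against the 4-methylphenyl group, a 1.7-fold lower number from compound 3 to compound 4 (0.22 log units; within the scatter) also stays inside it, whereas a 3.0-fold lower number from compound 2 to compound 4 (0.48 log units; beyond the scatter) is the first step in the set beyond the scatter, a modest gap between 3-bromophenyl and 4-cyanophenyl only. No data on hand account for these steps.

Still open, from the compounds shown here alone, is whether 4-bromophenyl would fall with the 3-bromophenyl group of compound 4 or the 2-bromophenyl group of compound 1. Also open, going by these compounds, is what an amine or a carboxylic acid on the phenyl ring would do.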